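This account rests on a few compounds, and the source may have more. Where it says the series, first, only, none or still open, it means among the compounds named here.

Of the compounds shown here, three have so far been tested in a functional assay on cells for agonist activity at C-X-C chemokine receptor type 4 (Homo sapiens), read by fluorescence and calcium flux, with a stated time of 90 s; a higher number here means that more compound is needed for the effect, a lower number that less compound is needed. Compound 1, `c1ccc(CN(CCCCN(C[C@H]2Cc3ccccc3CN2)[C@H]2CCCc3cccnc32)Cc2ccccn2)nc1`, gives in this assay a reading of > 30000 nM, which is a limit of the assay rather than a number. Compound 2, `c1ccc2c(c1)CN[C@@H](CN(CCCCNCC1CCCCC1)[C@H]1CCCc3cccnc31)C2`, gives in this assay > 30000 nM, again only a limit. Compound 3, `c1ccc2c(c1)CN[C@@H](CN(Cc1ccc(CNC3CCOCC3)cc1)[C@H]1CCCc3cccnc31)C2`, gives in this assay > 30000 nM, also a limit. Among the compounds with values here, compound 2 therefore stands exactly where every value shown stands, at the limit of > 30000 nM in this assay, at which 3 of the 3 values shown sit; nothing in the numbers sets it apart from compound 1 or compound 3, and no step between two measured compounds can be drawn from them.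

Compound 4, `C(=C/CN(C[C@H]1Cc2ccccc2CN1)[C@H]1CCCc2cccnc21)\CNCC1CCOCC1`, has not yet been measured. It differs from compound 2 by a group of 11 heavy atoms (9 carbon, 1 nitrogen, 1 oxygen; one six-membered non-aromatic ring with 1 hetero atom) in place of a group of 11 heavy atoms (10 carbon, 1 nitrogen; one six-membered non-aromatic ring of carbon only), on a saturated chain carbon bound to an amine nitrogen. Within the data shown here, no measured step exists to show what such a change does here, and the numbers give no sign of activity to build on. The expected step is a number no higher from compound 2 to compound 4 (the limit leaves the size open), which amounts to no change beyond the usual scatter. Compound 4 is thus expected to come out at about 30000 nM, within 10000 nM to 100000 nM, most probably reported once more as a limit.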

Compound 4, half-maximal effective concentration: > 30000 nM
Compound 4 was reported as a limit (the forecaster's own chance of this, stated with the estimate: 85%); the middle value lies on the limit itself.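

Compound 2 and compound 4 are both reported only as limits of the assay, so no step between them can be read: the limit of > 30000 nM in this assay, at which 4 of the 4 values shown sit.

The compounds shown leave open which structural change, if any, would give a measurable reading in this assay.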